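From a bromophenyl limit to a dimethylphenyl estimate

A few compounds are considered here, and "the series" means these few. Any claim that something is new, unique, unknown or untested is made for them only; others in the source may bear on it.

Values measured in a functional assay on WM 266-4 cells (Homo sapiens) for antiproliferative activity, read by MTT assay, with a stated time of 48 h (on this read-out higher numbers stand for weaker inhibition of growth and lower numbers for stronger inhibition of growth), are shown here, with compound 4 still open.

- Compound 1 `S=C(Nc1ccccc1)N1N=C(c2ccccc2)CC1c1ccc2c(c1)OCCO2` gives 3180 nM
- Compound 2 `Cc1ccc(C2=NN(C(=S)Nc3ccccc3)C(c3ccc4c(c3)OCCO4)C2)cc1` gives 10300 nM
- Compound 3 `S=C(Nc1ccccc1)N1N=C(c2ccccc2Br)CC1c1ccc2c(c1)OCCO2` gives > 200000 nM as a limit of the assay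
- Compound 4 `Cc1ccc(C2=NN(C(=S)Nc3ccccc3)C(c3ccc4c(c3)OCCO4)C2)cc1C` is not yet measured

Compound 3 sits at the limit of > 200000 nM in this assay, at which 1 of the 3 values shown sits, which is a limit and not a number. The change to compound 4 (3,4-dimethylphenyl in place of 2-bromophenyl on a carbon with a double bond to nitrogen) puts 3,4-dimethylphenyl in place of 2-bromophenyl on the carbon with a double bond to nitrogen. Within the data shown here, three measured steps bear on it. Bromo in place of hydrogen gave a large step (an at least 62-fold higher number from compound 1 to compound 3 (1.79 log units; beyond the scatter)) and 2-bromophenyl in place of 4-methylphenyl gave another (an at least 19-fold higher number from compound 2 to compound 3 (1.28 log units; beyond the scatter)). Methyl in place of hydrogen gave only a modest one (a 3.2-fold higher number from compound 1 to compound 2 (0.51 log units; beyond the scatter)). Compound 4 has no bromo and, like compound 2 (10300 nM), carries a methyl on its phenyl, so a large drop in the number is expected in this assay on leaving compound 3. The expected step is an at least 16-fold lower number from compound 3 to compound 4 (1.22 log units; beyond the scatter) toward stronger inhibition of growth. Compound 4 is estimated at 12000 nM (range 3500 nM to 45000 nM).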

Compound 4, concentration for 50% growth inhibition: 70500 nM
Compound 4: middle estimate off by 5.9-fold (0.77 log units), on the low side; the whole stated range lies below it.
By their numbers in this assay, from the lowest: compound 1; then compound 2; then compound 4. At a limit, above all of these: compound 3.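

In this assay, replacing 2-bromophenyl with 3,4-dimethylphenyl gives an at least 2.8-fold lower number from compound 3 to compound 4 (0.45 log units; beyond the scatter), a minimum only, as compound 3 is a limit and not a number. Losing the bromo therefore does not bring back the strength of compound 1, as a second methyl on the phenyl gives a 6.8-fold higher number from compound 2 to compound 4 (0.84 log units; beyond the scatter), and the full change from phenyl to 3,4-dimethylphenyl gives a 22-fold higher number from compound 1 to compound 4 (1.35 log units; beyond the scatter). Among the compounds shown, every group added to the phenyl on the carbon with a double bond to nitrogen raises the number, and none goes against this.

Going by these compounds, whether a methoxy, an amine or a carboxylic acid on this phenyl would do the same remains open. With a single bromo compound, the bromo itself also cannot be separated from its place on the ring.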